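Taking the Fluoro Group off Compound 2

The compounds below may be only part of what the source reports. "The series", "measured", "known", "first", "only" and "open" are said of these compounds alone.

Compound 1 `Fc1ccccc1CSc1nnc(-c2cnccn2)s1`: 32700 nM
Compound 2 `Fc1ccc(CSc2nnc(-c3cnccn3)s2)cc1`: > 50000 nM
Compound 3 `c1ccc(CSc2nnc(-c3cnccn3)s2)cc1`: not yet measured

In a functional assay on HeLa cells (Homo sapiens) for antiproliferative activity, read by MTT assay, with a stated time of 48 h (on this read-out lower numbers stand for stronger inhibition and higher numbers for weaker inhibition), compound 2 stands at > 50000 nM, which is a limit of the assay and not a number. Of the two tested compounds, only compound 1 has a measured number, 32700 nM.

Compound 3 differs from compound 2 in one place: hydrogen in place of fluoro on an aromatic carbon. This puts hydrogen in place of fluoro on an aromatic carbon, para to a large group.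

Going by the values given here, no measured step shows what this swap does, so only a small change is expected, with no firm direction beyond the scatter. Compound 1, at 32700 nM, is the nearest real number to lean on. The expected step of an at least 1.2-fold lower number from compound 2 to compound 3 (0.09 log units; that floor lies within the scatter) is a rough estimate, and another limit is quite possible. For compound 3, the estimated value is 40000 nM, with an expected range from 18000 nM to 70000 nM.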

Compound 3, half-maximal inhibitory concentration: 34400 nM
Compound 3: middle estimate off by 1.2-fold (0.07 log units), on the high side; measured number inside the range.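

Going by these compounds alone, with hydrogen on the ring, compound 3 gives the first step for this swap that rests on two real numbers in this assay: the swap from the fluoro group of compound 1 gives a 1.1-fold higher number from compound 1 to compound 3 (0.02 log units; within the scatter). At the place para to a large group, the same swap gives an at least 1.4-fold lower number from compound 2 to compound 3 (0.16 log units; that floor lies within the scatter), so this step shows no change beyond the scatter either. Compound 2 stands at a limit of the assay and not at a number, so this second step is only a floor: the limit of > 50000 nM in this assay, at which 1 of the 3 values shown sits.

The compounds shown leave open whether any other group at the place para to a large group, such as a methoxy group or an amine, would move the number beyond the scatter. They also leave open whether a larger halogen, such as chlorine or bromine, would do so.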